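The source may report more compounds than this note shows. Statements on the series, on what has been measured and on what is new or still open speak of the compounds shown alone.

Measured so far in an assay on isolated protein for inhibition of Amine oxidase [flavin-containing] B (Homo sapiens), read by fluorescence and Amplex Red, with stated times of 15 min and 20 min; a lower number here means a stronger inhibitor, a higher number a weaker inhibitor:
compound 1 `COc1ccc2c(=O)c(C(=O)NC3CCN(Cc4ccccc4)CC3)coc2c1` — 28600 nM
compound 2 `O=C(NC1CCN(Cc2ccccc2)CC1)c1coc2cc(Br)ccc2c1=O` — 19700 nM
compound 3 `COc1ccc2occ(C(=O)NCCC3CCN(Cc4ccccc4)CC3)c(=O)c2c1` — 11200 nM

Compound 3 gives the lowest of the three numbers; the gap to compound 2 lies within the scatter, the gap to compound 1 beyond it. Compound 4 `O=C(NCCC1CCN(Cc2ccccc2)CC1)c1coc2ccc(Br)cc2c1=O` differs from compound 3 by bromo in place of methoxy on an aromatic carbon. Going by the values given here, the one measured step of this kind is a 1.5-fold lower number from compound 1 to compound 2 (0.16 log units; within the scatter), a change too small to count. On that basis the step from compound 3 to compound 4 in this assay is expected to be a 1.3-fold lower number from compound 3 to compound 4 (0.12 log units; within the scatter), nothing beyond the scatter. Compound 4 is estimated at 8500 nM in this assay, with a range from 3000 nM to 25000 nM.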

Compound 4, half-maximal inhibitory concentration: 26100 nM
Beside the measured number, compound 4's estimate is 3.1-fold (0.49 log units) below it; the whole stated range lies below it.
By their numbers in this assay, from the lowest: compounds 3, 2, 4 and 1 (each within the scatter of the next, the first and the last beyond it).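

In this assay, going by these compounds alone, bromo in place of methoxy on an aromatic carbon gives a 2.3-fold higher number from compound 3 to compound 4 (0.37 log units; beyond the scatter), the first step of this change beyond the scatter. The change does not carry over from one core to the other: the same change on two cores in this assay, a 1.5-fold lower number (0.16 log units; within the scatter) from compound 1 to compound 2 and a 2.3-fold higher number (0.37 log units; beyond the scatter) from compound 3 to compound 4, 3.4-fold (0.53 log units) apart, beyond the scatter of two such steps

Compound 1 and compound 3 differ in more than one place, and the compounds shown do not separate the contributions of those differences to this gap. From the compounds shown here alone, how an amine or a carboxylic acid on this aromatic carbon would read on either core also remains open.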